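Halogen pattern swap on the benzyl ether of compound 3

The source may hold more compounds than are shown below. What is called first, only, known or untested is meant among the compounds shown, and "the series" means these compounds.

Three analogues sharing one core have been measured in an assay on CHO cells for binding affinity to metabotropic glutamate receptor 2 (Rattus norvegicus); on this read-out higher numbers stand for weaker inhibition and lower numbers for stronger inhibition. Compound 1 `Nc1cccc(CO[C@@H]2C[C@@H]3[C@H]([C@]2(N)C(=O)O)[C@@]3(F)C(=O)O)c1` gives 15.4 nM. Compound 2 `N[C@]1(C(=O)O)[C@H]2[C@@H](C[C@H]1OCc1cccc(F)c1F)[C@]2(F)C(=O)O` gives 4.25 nM, and compound 3 `N[C@]1(C(=O)O)[C@H]2[C@@H](C[C@H]1OCc1ccc(Cl)cc1Cl)[C@]2(F)C(=O)O` gives 3.89 nM. Compound 3 sits at the low end of these three numbers: the step of a 4.0-fold lower number from compound 1 to compound 3 (0.60 log units; beyond the scatter) lies beyond the scatter, whereas the step of a 1.1-fold lower number from compound 2 to compound 3 (0.04 log units; within the scatter) does not, so compound 2 and compound 3 cannot be told apart on this read-out.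

Compound 4 `N[C@]1(C(=O)O)[C@H]2[C@@H](C[C@H]1OCc1ccc(F)c(Cl)c1)[C@]2(F)C(=O)O` differs from compound 3 by 3-chloro-4-fluorophenyl in place of 2,4-dichlorophenyl on a saturated chain carbon bound to an oxygen on a saturated carbon. The step that bears most directly on this change is the one between the two dihalophenyl compounds, a 1.1-fold lower number from compound 2 to compound 3 (0.04 log units; within the scatter), which was within the scatter. The two larger steps, a 3.6-fold lower number from compound 1 to compound 2 (0.56 log units; beyond the scatter) and a 4.0-fold lower number from compound 1 to compound 3 (0.60 log units; beyond the scatter), both concern the replacement of 3-aminophenyl by a dihalophenyl group and are not repeated here, since compound 4 keeps a dihalophenyl group. On that basis no step beyond the scatter is expected in this assay for compound 4, and the expected step is a 1.2-fold higher number from compound 3 to compound 4 (0.06 log units; within the scatter). The estimate for compound 4 in this assay is 4.5 nM, with a range from 1.8 nM to 11 nM.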

Compound 4, inhibition constant: 3.57 nM
Beside the measured number, compound 4's estimate is 1.3-fold (0.10 log units) above it, within the range that was stated.
By their numbers in this assay, from the lowest: compounds 4, 3 and 2 (each within the scatter of the next); then compound 1.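

Compound 4 carries chlorine and fluorine together on the ring, where compound 2 has only fluorine and compound 3 only chlorine, yet in this assay the change gives a 1.1-fold lower number from compound 3 to compound 4 (0.04 log units; within the scatter) and, measured against the 2,3-difluorophenyl group, a 1.2-fold lower number from compound 2 to compound 4 (0.08 log units; within the scatter), so the three dihalophenyl groups cannot be told apart at this position on a saturated chain carbon bound to an oxygen. The separation from the 3-aminophenyl group now holds for a third dihalophenyl group, with a 4.3-fold lower number from compound 1 to compound 4 (0.63 log units; beyond the scatter) as the step beyond the scatter, and none of the four compounds goes against this division. No supporting evidence bears on why these halogen patterns give values that cannot be told apart.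

The compounds shown leave open how a phenyl ring with no substituent or with a single chlorine would compare, so they do not settle whether the gap to compound 1 reflects the amine or the absence of halogen. They also leave open how a methoxy group, a nitrile, a carboxylic acid on the ring or a longer chain to the ring would fare here.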